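A few compounds are considered here, and "the series" means these few. Any claim that something is new, unique, unknown or untested is made for them only; others in the source may bear on it.

Compound 2 `CCC1(Cc2ccccc2)OS(=O)(=O)C=C1OCc1ccccc1Cl` and compound 1 `CCC1(Cc2ccccc2)OS(=O)(=O)C=C1OCCCCc1ccccc1` share one core and differ only in the group on a saturated chain carbon bound to an oxygen on an unsaturated carbon. In an ADME assay on HEL cells (Homo sapiens) for cytotoxicity, with a stated time of 3 days (on this read-out higher numbers stand for lower toxicity in this test and lower numbers for higher toxicity in this test), compound 1 gives 99000 nM, while compound 2 gives 38000 nM. The step of a 2.6-fold lower number from compound 1 to compound 2 (0.42 log units; beyond the scatter) leaves compound 2 with the lowest of the two numbers, that is, the greater toxicity seen so far in this assay. Compound 3 `CCC1(Cc2ccccc2)OS(=O)(=O)C=C1OCc1ccc(Br)cc1` keeps the core of compound 2 but carries 4-bromophenyl in place of 2-chlorophenyl on a saturated chain carbon bound to an oxygen on an unsaturated carbon. Among the compounds with values here, the only measured step, a 2.6-fold lower number from compound 1 to compound 2 (0.42 log units; beyond the scatter), exchanged 3-phenylpropyl for 2-chlorophenyl and so says little about trading one ring for another of the same size with a different halogen. With no direct guide, the expected step is a 1.1-fold higher number from compound 2 to compound 3 (0.02 log units; within the scatter), small enough to sit within the usual scatter. Compound 3 is therefore estimated at 40000 nM in this assay, within a range of 15000 nM to 100000 nM.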

Compound 3, half-maximal cytotoxic concentration: 171000 nM
Compound 3: middle estimate off by 4.3-fold (0.63 log units), on the low side; the measured number lies above the stated range.
By their numbers in this assay, from the lowest: compound 2; then compounds 1 and 3 (each within the scatter of the next).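

In this assay, the change from 2-chlorophenyl to 4-bromophenyl gives a 4.5-fold higher number from compound 2 to compound 3 (0.65 log units; beyond the scatter), so at this position two groups with the same count of heavy atoms and one aromatic ring each can still differ beyond the scatter. With a 1.7-fold higher number from compound 1 to compound 3 (0.24 log units; within the scatter), which lies within the scatter, 3-phenylpropyl and 4-bromophenyl cannot be told apart, leaving compound 2 alone as the most toxic in this test of the three. Nothing available explains why these groups behave as they do.

Both the halogen and its place on the ring change in this step, so the compounds shown cannot say which of the two matters; 4-chlorophenyl and 2-bromophenyl groups would separate them. Also open, going by these compounds, is how a plain phenyl ring or an aminophenyl group would read at this position.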